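Swapping the benzyl substituent on a piperazine-linked core

A few compounds are considered here, and "the series" means these few. Any claim that something is new, unique, unknown or untested is made for them only; others in the source may bear on it.

Measured so far:
compound 1 `N#Cc1ccccc1N1CCN(c2nc(=O)c3cc(C(F)(F)F)cc([N+](=O)[O-])c3s2)CC1`: 14.1 mL.min-1.g-1
compound 2 `N#Cc1cccc(CN2CCN(c3nc(=O)c4cc(C(F)(F)F)cc([N+](=O)[O-])c4s3)CC2)c1`: 23.2 mL.min-1.g-1

In an ADME assay on microsomes from liver (Homo sapiens) for metabolic stability, with a stated time of 90 min, tested at 20 uM (on this read-out lower numbers stand for slow clearance and higher numbers for fast clearance), compound 1 gives 14.1 mL.min-1.g-1, and compound 2 gives 23.2 mL.min-1.g-1. Only these two numbers exist, so compound 2 stands beside compound 1 alone: the step of a 1.6-fold higher number from compound 1 to compound 2 (0.22 log units; within the scatter) is within the scatter, and the two compounds are not told apart by this assay.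

Compound 3 `O=c1nc(N2CCN(Cc3ccc(OC(F)(F)F)cc3)CC2)sc2c([N+](=O)[O-])cc(C(F)(F)F)cc12` is not yet measured. It differs from compound 2 in one place: 4-(trifluoromethoxy)phenyl in place of 3-cyanophenyl on a saturated chain carbon bound to an amine nitrogen in a ring. Among the compounds with values here, the single measured step, from compound 1 to compound 2, exchanges a different group at a different place and does not bear on this change. Within the data shown here, with no measured step to lean on, the expectation for compound 3 rests on compound 2 alone, and no shift beyond the scatter is expected: a 1.1-fold higher number from compound 2 to compound 3 (0.03 log units; within the scatter). Compound 3 is therefore estimated at 25 mL.min-1.g-1, with a range from 10 mL.min-1.g-1 to 60 mL.min-1.g-1.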

Compound 3, intrinsic clearance in microsomes: 32.1 mL.min-1.g-1
Compound 3: middle estimate off by 1.3-fold (0.11 log units), on the low side, and the stated range covers the measured number.
By their numbers in this assay, from the lowest: compounds 1, 2 and 3 (each within the scatter of the next, the first and the last beyond it).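

In this assay, 4-(trifluoromethoxy)phenyl in place of 3-cyanophenyl gives a 1.4-fold higher number from compound 2 to compound 3 (0.14 log units; within the scatter) and so does not separate the two benzyl groups, although the entering group has 11 heavy atoms and the leaving group 8. Within the data shown here, with 4-(trifluoromethoxy)benzyl in place of 2-cyanophenyl on an amine nitrogen in a ring, the result is a 2.3-fold higher number from compound 1 to compound 3 (0.36 log units; beyond the scatter) and is the only step here beyond the scatter, though a modest one, while compound 2 lies within the scatter of both other compounds. Nothing available explains why clearance differs between these compounds.

Still open, as far as these compounds go, is how an amine or a carboxylic acid on the benzyl ring would compare. A longer chain between the aromatic ring and the amine nitrogen in a ring is also untested by these compounds.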